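Replacing the 1H-imidazol-1-yl group of compound 3

A few compounds are considered here, and "the series" means these few. Any claim that something is new, unique, unknown or untested is made for them only; others in the source may bear on it.

Compound 1 `Cc1cn(-c2ccc(Cn3cc(C(=O)O)c(=O)c4cccnc43)cc2)cn1`: 94.8%
Compound 2 `O=C(O)c1cn(Cc2ccc(-c3ccccc3)cc2)c2ccsc2c1=O`: 99.2%
Compound 3 `O=C(O)c1cn(Cc2ccc(-n3ccnc3)cc2)c2ccsc2c1=O`: 74.1%

All three compounds were tested in an ADME assay on the whole organism (serum) for protein binding, with Rattus norvegicus as the target, using equilibrium dialysis. Of these, compound 3 leaves the largest share free in serum, with a reading of 74.1%. Its nearest neighbour is compound 1 and its furthest is compound 2.

In compound 4 `Cn1cc(-c2ccc(Cn3cc(C(=O)O)c(=O)c4sccc43)cc2)cn1`, one group changes 1-methyl-1H-pyrazol-4-yl in place of 1H-imidazol-1-yl on an aromatic carbon. Within the data shown here, only one measured step bears on this place, a 32-fold higher unbound fraction from compound 2 to compound 3 (1.51 log units; beyond the scatter), when 1H-imidazol-1-yl replaced phenyl. That step was large, so a change at this place can shift binding a long way. It involved a different incoming group, however, so it cannot simply be carried over. The entering and leaving groups are each one five-membered aromatic ring with 2 hetero atoms, so a smaller move seems likely. Compound 3, at 74.1%, is at the free end of the measured range, so any move is expected to go back towards more binding. The expected change is a 3.2-fold lower unbound fraction from compound 3 to compound 4 (0.51 log units; beyond the scatter), only part of the earlier step. The estimate for compound 4 is 92%, with an expected range from 82% to 97.5%.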

Compound 4, plasma protein binding: 99.1%
Compound 4: middle estimate off by 8.9-fold (0.95 log units) (unbound fraction), on the high side, outside the stated range (above it).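

In this assay the change from 1H-imidazol-1-yl to 1-methyl-1H-pyrazol-4-yl gives a 29-fold lower unbound fraction from compound 3 to compound 4 (1.46 log units; beyond the scatter) at this place, so two groups can share one five-membered aromatic ring with 2 hetero atoms and the same counts of hydrogen-bond donors and acceptors, yet behave very differently. Set against phenyl, the new group gives a 1.1-fold higher unbound fraction from compound 2 to compound 4 (0.05 log units; within the scatter) and thus leaves compound 4 indistinguishable from compound 2, which shows that the large gain in free compound seen for compound 3 does not come with every replacement of phenyl by such a five-membered ring. No measurement shown here explains why these two rings differ so much.

The compounds shown leave open whether the gap between compound 3 and compound 4 follows the methyl group or the ring itself and the way it is attached, and the unsubstituted 1H-pyrazol-4-yl group would be one way to separate these. Going by these compounds, how an amine or a carboxylic acid at this place would shift binding in this assay also remains open.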